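The source may hold more compounds than are shown below. What is called first, only, known or untested is meant among the compounds shown, and "the series" means these compounds.

In a functional assay on HL-60 cells (Homo sapiens) for antiproliferative activity, read by MTT assay, with a stated time of 24 h (on this read-out lower numbers stand for stronger inhibition and higher numbers for weaker inhibition), compound 1 `CCCCc1oc2ccccc2c1C(=O)c1ccc(OCC(=O)NC(C)C)cc1` gives 360 nM. Compound 2 `CCCCc1oc2ccccc2c1C(=O)c1ccc(OCC(=O)N2CCCC2)cc1` reports only a limit, > 50000 nM, and so stands at the limit of > 50000 nM in this assay, at which 2 of the 3 values shown sit. Compound 3 `CCCCc1oc2ccccc2c1C(=O)c1ccc(OCC(=O)N2CCN(C(=O)OC(C)(C)C)CC2)cc1` likewise reports only a limit, > 50000 nM. The change from compound 2 to compound 4 `CCCCc1oc2ccccc2c1C(=O)c1ccc(OCC(=O)N[C@H](C)c2ccccc2)cc1` is (1-phenylethyl)amino in place of pyrrolidin-1-yl on a carbonyl carbon. This restores an amide hydrogen, as in compound 1. Among the measured compounds shown here, one measured step bears on the change: going from isopropylamino to pyrrolidin-1-yl gave an at least 130-fold higher number from compound 1 to compound 2 (2.14 log units; beyond the scatter), a large step. Compound 4 is expected to reverse much of it, though (1-phenylethyl)amino is not isopropylamino, so the size remains uncertain. The expected step toward a lower number is large, an at least 33-fold lower number from compound 2 to compound 4 (1.52 log units; beyond the scatter). In this assay the estimated value for compound 4 is 1500 nM, with a range of 150 nM to 25000 nM.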

Compound 4, half-maximal inhibitory concentration: > 50000 nM
Compound 4: no number, only a limit; the forecaster's own chance of this, stated with the estimate: 25%; middle value at least 33-fold (1.52 log units) away from the limit.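

In this assay, 1-phenylethyl in place of isopropyl on an amide-type nitrogen gives an at least 130-fold higher number from compound 1 to compound 4 (2.14 log units; beyond the scatter). An amide hydrogen is therefore not enough on its own at this position, and what is attached to that nitrogen matters as well. Compound 4 reports only a limit, so the step from compound 2 cannot be read: the limit of > 50000 nM in this assay, at which 3 of the 4 values shown sit.

Isopropyl remains the only group here that gives a number. From the compounds shown here alone, it stays open whether cyclopropyl, tert-butyl or the opposite stereocentre of 1-phenylethyl on that nitrogen would give one too.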